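Adding a Methoxymethyl Group to the Fluoro Compound

The compounds below may be only part of what the source reports. "The series", "measured", "known", "first", "only" and "open" are said of these compounds alone.

Compound 1, `c1ccc(Nc2c(-c3ccccn3)nc3ccccn23)cc1`, in an ADME assay on THP-1 cells (Homo sapiens) for cytotoxicity (on this read-out lower numbers stand for higher toxicity in this test and higher numbers for lower toxicity in this test), gives 6690 nM.
Compound 2, `Fc1cccc(Nc2c(-c3ccccn3)nc3ccccn23)c1`, in this assay gives only a limit, > 50000 nM.

Compound 2 therefore stands at the limit of > 50000 nM in this assay, at which 1 of the 2 values shown sits; its true value is not known, only that it lies at or beyond that limit. Compound 3, `COCc1ccc2nc(-c3ccccn3)c(Nc3cccc(F)c3)n2c1`, differs from compound 2 by a single change: methoxymethyl in place of hydrogen on an aromatic carbon.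

Within the data shown here, only one measured step exists, an at least 7.4-fold higher number from compound 1 to compound 2 (0.87 log units; beyond the scatter), and it concerns a different change at a different place, so it says little about adding a methoxymethyl. Among the measured compounds shown here, with no measured step that bears on this change, the expectation is no shift beyond the scatter, that is a number no higher from compound 2 to compound 3 (the limit leaves the size open). Compound 3 is thus estimated at 50000 nM, within a range from 20000 nM to 150000 nM, and it may well again be reported only as a limit.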

Compound 3, half-maximal cytotoxic concentration: 16000 nM
Compound 3: middle estimate off by 3.1-fold (0.49 log units), on the high side, and the stated range ends above it.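

Methoxymethyl on this aromatic carbon, part of the six-membered aromatic ring with 1 nitrogen, gives the first view of a change at this place on the shared core: in this assay there is an at least 3.1-fold lower number from compound 2 to compound 3 (0.49 log units; beyond the scatter). A lower number here means higher toxicity in this test, so this change runs in the opposite direction to the earlier fluoro step, an at least 7.4-fold higher number from compound 1 to compound 2 (0.87 log units; beyond the scatter). The value of compound 2 is a limit, so the new step gives only a minimum size: the limit of > 50000 nM in this assay, at which 1 of the 3 values shown sits.

From the compounds shown here alone, with one group at this carbon, it remains open whether the shift is specific to methoxymethyl or whether an amine, a carboxylic acid or a longer chain there would move the number in the same way. Also open, going by these compounds, is whether the same change would lower the number on compound 1, which has no fluoro.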